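Notes on aryl-to-ethyl change in a reporter series

The compounds below may be only part of what the source reports. "The series", "measured", "known", "first", "only" and "open" are said of these compounds alone.

Measured compounds:
- compound 1 `Cc1ccc(-c2nc3sccn3c2/C=N/OCc2ccc(Cl)c(Cl)c2)cc1`: 490 nM
- compound 2 `Clc1ccc(CO/N=C/c2c(-c3cccc4ccccc34)nc3sccn23)cc1Cl`: 940 nM

In an assay on HepG2 cells for agonist activity at nuclear receptor subfamily 1 group I member 3 (Homo sapiens), read by a luciferase reporter, with a stated time of 23 h (a higher number here means that more compound is needed for the effect, a lower number that less compound is needed), compound 1 gives 490 nM and compound 2 gives 940 nM. Among the measured compounds shown here, compound 2 has the higher of the two numbers, but the only step, a 1.9-fold higher number from compound 1 to compound 2 (0.28 log units; within the scatter), is within the scatter, so the two compounds cannot be ordered.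

Compound 3 `CCc1nc2sccn2c1/C=N/OCc1ccc(Cl)c(Cl)c1` differs from compound 2 by ethyl in place of naphthalen-1-yl on an aromatic carbon. For the measured compounds named here, the one measured step on this carbon, a 1.9-fold higher number from compound 1 to compound 2 (0.28 log units; within the scatter), exchanged one aryl group for another and left the number essentially unchanged; no measured step removes the aryl group altogether, so its bearing on the present change is limited. The expectation for compound 3 is therefore a step of a 1.6-fold higher number from compound 2 to compound 3 (0.20 log units; within the scatter), a modest rise in number with wide uncertainty in both directions. In this assay compound 3 is estimated at 1500 nM, with a range from 400 nM to 6000 nM.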

Compound 3, half-maximal effective concentration: 2600 nM
The estimate for compound 3 lay 1.7-fold (0.24 log units) below the measured number; low and high end bracket the measured number.
By their numbers in this assay, from the lowest: compounds 1 and 2 (each within the scatter of the next); then compound 3.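

In this assay, putting ethyl on this aromatic carbon in place of an aryl group moves the number beyond the scatter, which the exchange of one aryl group for another did not do: the change gives a 2.8-fold higher number from compound 2 to compound 3 (0.44 log units; beyond the scatter) and a 5.3-fold higher number from compound 1 to compound 3 (0.72 log units; beyond the scatter) in the two comparisons. Naphthalen-1-yl and 4-methylphenyl, which cannot be ordered against each other, therefore both give lower numbers than ethyl, though both steps are modest and compound 3 still gives a measured number. No measurement shown explains the rise.

The compounds shown do not separate the loss of the aromatic ring from the loss of carbon atoms. A cyclohexyl group or a longer chain at this carbon would address that, and a phenyl ring carrying an amine or a carboxylic acid would test whether the aryl position accepts a charged group.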